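The source may report more compounds than this note shows. Statements on the series, on what has been measured and on what is new or still open speak of the compounds shown alone.

Of the compounds shown here, three have been tested in a functional assay on DU-145 cells (Homo sapiens) for cytotoxicity, read by trypan blue exclusion, with a stated time of 96 h; on this read-out lower numbers stand for stronger inhibition and higher numbers for weaker inhibition. Compound 1 `COc1cc(OC)c(/C=C/S(=O)(=O)Cc2ccc(F)c([N+](=O)[O-])c2)c(OC)c1` gives 25000 nM. Compound 2 `COC(=O)C(C)(C)Nc1cc(CS(=O)(=O)/C=C/c2c(OC)cc(OC)cc2OC)ccc1OC` gives 2500 nM, the lowest of the three numbers, though its gap to compound 3 `COc1ccc(CS(=O)(=O)/C=C/c2cc(OC)c(OC)c(OC)c2)cc1NCC(=O)O`, which gives 5000 nM, lies within the usual scatter; only its gap to compound 1 lies beyond it. Compound 4 `COc1cc(OC)c(/C=C/S(=O)(=O)Cc2ccc(OC)c(NC(C(=O)O)c3ccc(Cl)cc3)c2)c(OC)c1` has not yet been measured. It differs from compound 2 in one place: carboxy(4-chlorophenyl)methyl in place of 1-(methoxycarbonyl)-1-methylethyl on a nitrogen on an aromatic ring. Within the data shown here, no measured pair shows a change of this kind, so its direction is open. The step expected from compound 2 to compound 4 is a 1.6-fold higher number from compound 2 to compound 4 (0.20 log units; within the scatter), a small shift towards weaker inhibition that is expected to stay within the scatter. Compound 4 is estimated at 4000 nM, with a range from 1200 nM to 15000 nM.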

Compound 4, half-maximal inhibitory concentration: 400 nM
For compound 4 the middle estimate is 10-fold (1.00 log units) above the measured one; the measured number lies below the stated range.
By their numbers in this assay, from the lowest: compound 4; then compounds 2 and 3 (each within the scatter of the next); then compound 1.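

On a nitrogen on an aromatic ring, carboxy(4-chlorophenyl)methyl in place of 1-(methoxycarbonyl)-1-methylethyl gives a 6.3-fold lower number from compound 2 to compound 4 (0.80 log units; beyond the scatter) in this assay, a step towards stronger inhibition. Among these compounds, this shows that the group on this nitrogen can shift the result beyond the scatter, which no earlier pair could show. Nothing shown here explains the shift.

As far as these compounds go, the change brings in an aromatic ring, a chlorine and a carboxy group together, so the share of each stays open. A plain phenyl without the chlorine, or an amide in place of the carboxy group, would be needed to separate them.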